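The compounds below may be only part of what the source reports. "The series", "measured", "known", "first", "only" and "open" are said of these compounds alone.

Measured so far in a functional assay on MCF7 cells (Homo sapiens) for cytotoxicity, read by MTT assay, with a stated time of 96 h; on this read-out lower numbers stand for stronger inhibition and higher numbers for weaker inhibition:
- compound 1 `COc1cc(C(=O)c2cn(-c3cccc(C)c3)cc2-c2cccc([N+](=O)[O-])c2)cc(OC)c1OC` gives 880 nM
- compound 2 `COc1cc(C(=O)c2cn(-c3cccc(C)c3)cc2-c2cccc(N)c2)cc(OC)c1OC` gives 130 nM

Of these two numbers, compound 2 has the lower (130 nM) and therefore stands as the stronger inhibitor in this assay. Among the compounds with values here, the only measured step is a 6.8-fold lower number from compound 1 to compound 2 (0.83 log units; beyond the scatter), with amino in place of nitro on an aromatic carbon. It is modest but beyond the scatter.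

Compound 3 `COc1cc(C(=O)c2cn(-c3ccc(F)cc3)cc2-c2cccc(N)c2)cc(OC)c1OC` keeps the 3-aminophenyl group and differs elsewhere, with 4-fluorophenyl in place of 3-methylphenyl on an aromatic nitrogen of a five-membered aromatic ring with 1 nitrogen: 4-fluorophenyl in place of 3-methylphenyl on an aromatic nitrogen. Within the data shown here, the measured step changes a different place, so it says nothing about the size of this one, and no measured pair varies the group on that nitrogen. With no evidence for a direction, no step beyond the scatter is expected, and the range is kept wide. The expected step is a 1.1-fold lower number from compound 2 to compound 3 (0.03 log units; within the scatter), which is only a small estimated shift. Compound 3 is estimated at 120 nM in this assay, with an expected range from 35 nM to 420 nM.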

Compound 3, half-maximal inhibitory concentration: 53 nM
Estimate against measurement, compound 3: 2.3-fold (0.35 log units) above; the range from low to high includes it.
By their numbers in this assay, from the lowest: compound 3; then compound 2; then compound 1.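

In this assay, within the data shown here, the group on the aromatic nitrogen of the five-membered ring proves able to move the number: 4-fluorophenyl in place of 3-methylphenyl gives a 2.5-fold lower number from compound 2 to compound 3 (0.39 log units; beyond the scatter) and carries the series to its lowest value so far. Compound 1 and compound 2 differ only in amino against nitro on an aromatic carbon, so they said nothing about this place, two ring bonds from the ring atom that bears the 3-aminophenyl group. No measurement at hand bears on why this change lowers the number.

This single pair changes the substituent and its place on the ring together, so it cannot separate the arrival of fluorine from the departure of methyl or from the shift in where the substituent stands. The compounds shown also leave open how 3-fluorophenyl, 4-methylphenyl or unsubstituted phenyl would compare on that nitrogen, and whether 4-fluorophenyl would give a step of similar size with nitro in place of amino on the other aromatic ring.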